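Adding a Second Chloro to the Core of Compound 3

The source may hold more compounds than are shown below. What is called first, only, known or untested is meant among the compounds shown, and "the series" means these compounds.

Of the compounds shown here, three have been tested in a functional assay on ACHN cells (Homo sapiens) for cytotoxicity, read by sulforhodamine B assay, with a stated time of 48 h; on this read-out lower numbers stand for higher toxicity in this test and higher numbers for lower toxicity in this test. Compound 1 `ClCc1ccccc1Cn1cnc2c(Cl)nc(Cl)nc21` gives 4160 nM, compound 2 `ClCc1ccccc1Cn1cnc2c(Cl)ncnc21` gives 26900 nM, and compound 3 `ClCc1cccc(Cn2cnc3c(Cl)ncnc32)c1` gives 8120 nM. Compound 2 and compound 1 differ in only one place, namely (chloro in place of hydrogen on an aromatic carbon), and this change brought a 6.5-fold lower number from compound 2 to compound 1 (0.81 log units; beyond the scatter). Compound 3 is built from the same atoms as compound 2, joined differently; the difference between the two cores is not broken down here, and the two values only show that compound 3 stands lower than compound 2. Compound 1 and compound 3 lie within the usual scatter of each other.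

Compound 4 `ClCc1cccc(Cn2cnc3c(Cl)nc(Cl)nc32)c1` has not yet been measured. It differs from compound 3 by chloro in place of hydrogen on an aromatic carbon. The surroundings of the change are described word for word as for the earlier pair, so this is the same change as from compound 2 to compound 1. In this assay the step from compound 3 to compound 4 is expected to be a 6.2-fold lower number from compound 3 to compound 4 (0.80 log units; beyond the scatter), because the same change gave a 6.5-fold lower number from compound 2 to compound 1 (0.81 log units; beyond the scatter). Compound 4 is therefore expected at about 1300 nM, most likely between 500 nM and 3500 nM.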

Compound 4, concentration lethal to 50% of the cells: 7240 nM
Compound 4: the middle estimate sits 5.6-fold (0.75 log units) below what was measured; measured number above the stated range.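

In this assay, chloro in place of hydrogen on an aromatic carbon gave a 1.1-fold lower number from compound 3 to compound 4 (0.05 log units; within the scatter), so on this core the added chloro produced no change that can be told from the scatter. The same change therefore did not carry its size over from one core to the other, even though the two sites are described in identical words: the same change on two cores in this assay, a 6.5-fold lower number (0.81 log units; beyond the scatter) from compound 2 to compound 1 and a 1.1-fold lower number (0.05 log units; within the scatter) from compound 3 to compound 4, 5.8-fold (0.76 log units) apart, beyond the scatter of two such steps This shows that, in this series, a step measured on one core is not a safe guide to the same step on a closely related core, but two pairs cannot show why the steps differ or predict what a further core would do.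

The compounds shown leave open whether an amine or a methoxy group on the aromatic carbon between two ring nitrogen atoms would also give different steps on the two cores. They also leave open whether the two cores would still respond differently to the added chloro if a hydroxymethyl group took the place of the chloromethyl group.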